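Removing the carbamoylmethyl side chain in the purine amide series

This account rests on a few compounds, and the source may have more. Where it says the series, first, only, none or still open, it means among the compounds named here.

Compound 1 `CC[C@H](C)[C@H](NC(=O)CN(c1nc(Cl)nc2[nH]cnc12)C1CC1)C(=O)O` and compound 2 `NC(=O)C[C@H](NC(=O)CN(c1nc(Cl)nc2[nH]cnc12)C1CC1)C(=O)O` share one core and differ only at the saturated chain carbon bound to an amide-type nitrogen and a carbonyl carbon. In a functional assay on the whole organism (Tail, strain ICR) with Mus musculus as the target, in the tail flick test, with a stated time of 90 min, at a dose of 25 umol/kg by the oral route (on this read-out higher numbers stand for a stronger effect at the one dose given and lower numbers for a weaker effect), compound 1 gives 27.4% and compound 2 gives 20.1%, the change reading a number 7.3 percentage points lower from compound 1 to compound 2 (within the scatter). Compound 3 `O=C(O)CNC(=O)CN(c1nc(Cl)nc2[nH]cnc12)C1CC1` carries hydrogen in place of carbamoylmethyl on a saturated chain carbon bound to an amide-type nitrogen and a carbonyl carbon. Among the compounds with values here, the only step measured at this place, a number 7.3 percentage points lower from compound 1 to compound 2 (within the scatter), stayed within the scatter. No step beyond the scatter is therefore expected for a number 0.1 percentage points lower from compound 2 to compound 3 (within the scatter). Compound 3 is estimated at 20% in this assay, with a range from 8% to 34%.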

Compound 3, a percentage reported as activity, at one dose (the size of the read-out at that dose, not a potency): 32.3%
The estimate for compound 3 lay 12.3 percentage points below the measured number; the range from low to high includes it.
By their numbers in this assay, from the lowest: compounds 2, 1 and 3 (each within the scatter of the next, the first and the last beyond it).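

In this assay, within the data shown here, hydrogen in place of carbamoylmethyl on the saturated chain carbon bound to an amide-type nitrogen and a carbonyl carbon gives the first step at this place beyond the scatter (a number 12.2 percentage points higher from compound 2 to compound 3 (beyond the scatter)). Hydrogen in place of sec-butyl stays within the scatter (a number 4.9 percentage points higher from compound 1 to compound 3 (within the scatter)), so the read-out at the one dose given holds here without a side chain on this carbon. Nothing available bears on the cause of these steps.

As far as these compounds go, how a carboxymethyl, an aminoalkyl or a longer unbranched alkyl chain on this carbon would read remains open. So does whether the step seen with carbamoylmethyl would hold at other doses or times.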